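The source may report more compounds than this note shows. Statements on the series, on what has been measured and on what is new or still open speak of the compounds shown alone.

Series notes. Compound 1 `CC(C)c1cccc2nc(N3CCN(C)CC3)oc12` and compound 2 `CN1CCN(c2nc3cc(C(C)(C)C)ccc3o2)CC1` carry a branched alkyl on the aromatic ring of the shared core, while compound 3 `Cc1cc(C)c2oc(N3CCN(C)CC3)nc2c1` carries two methyls instead. In a functional assay on ileum (strain Hartley) for agonist activity at 5-hydroxytryptamine receptor 3A (Cavia porcellus) (on this read-out lower numbers stand for lower potency and higher numbers for higher potency (the scale is a negative logarithm)), compound 3 gives 6.32. Compound 1 reaches only the limit of this assay, recorded as < 4. Compound 2 likewise stops at the limit of this assay, recorded as < 4. Within the data shown here, compound 2 therefore stands at the limit of < 4 in this assay, at which 2 of the 3 values shown sit, with no number of its own, and the only measured value in the set belongs to compound 3.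

Compound 4 `CN1CCN(c2nc3cc(N)ccc3o2)CC1` differs from compound 2 in one place: amino in place of tert-butyl on an aromatic carbon. Among the measured compounds shown here, no pair of measured compounds separated by a single change is available, so the size of this kind of step cannot be read from the data. Compound 2 starts at a limit rather than at a number. The step from compound 2 to compound 4 is expected to be a number at least 0.50 log units higher from compound 2 to compound 4 (beyond the scatter), upward and modest. Compound 4 is expected to give about 4.5 in this assay, within 3.7 to 5.5, and a report of only a limit remains plausible.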

Compound 4, negative logarithm of the half-maximal effective concentration: 4.97
Compound 4: the middle estimate sits 0.47 log units below what was measured; the measured number falls inside the stated range.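

In this assay, amino in place of tert-butyl on an aromatic carbon gives a number at least 0.97 log units higher from compound 2 to compound 4 (beyond the scatter). Substitution on this carbon, meta to a fused ring and para to a fused ring, therefore does not by itself hold a compound at the limit, and the outcome there depends on the group carried. The size of the step remains a minimum, as its starting point is a limit and not a number: the limit of < 4 in this assay, at which 2 of the 4 values shown sit.

The change removes tert-butyl and introduces amino in one step, so the contribution of each cannot be separated. A methoxy or dimethylamino group on this carbon would show whether the measurable potency of compound 4 is specific to amino or extends to other small groups.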